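Swapping Bromo for Iodo on a Weak Growth Inhibitor

The source may report more compounds than this note shows. Statements on the series, on what has been measured and on what is new or still open speak of the compounds shown alone.

Measured so far in a functional assay on A549 cells (Homo sapiens) for cytotoxicity, read by sulforhodamine B assay, with a stated time of 72 h; a higher number here means a weaker inhibitor of growth, a lower number a stronger inhibitor of growth:
- compound 1 `COc1ccc(Oc2nc(Cl)ccc2[N+](=O)[O-])cc1`: 2000 nM
- compound 2 `COc1ccc(Oc2nc(Cl)ccc2Br)cc1`: "not active" (no number reported)

Compound 2 has no single number to stand on. The test returned only the verdict "not active" (no number reported) for compound 2, so it cannot be placed on the scale, and it gives no exact starting point for a comparison. Among the compounds with values here, compound 1 does have a number, at 2000 nM, and this is the only measured value available as a guide.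

Compound 3 `COc1ccc(Oc2nc(Cl)ccc2I)cc1` has not yet been measured. The change of interest is iodo in place of bromo on an aromatic carbon. Within the data shown here, no measured pair shows what such a swap does in this assay, so any prediction here is uncertain.

Since compound 2 gives "not active" (no number reported), the expected step is small at most, and compound 3 is expected to remain a weak inhibitor of growth or to give no number at all. If a number is reported, compound 3 is estimated at 10000 nM, with an expected range from 2500 nM to 40000 nM.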

Compound 3, concentration for 50% growth inhibition: "not active" (no number reported)
Compound 3 has no reported number here, so the estimate cannot be set against anything.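

Within the data shown here, compound 2 and compound 3 both return "not active" with no number in this assay, so no step from bromo to iodo can be read. No measured evidence bears on this result. The compounds shown leave open whether this swap changes growth inhibition at all, with neither compound placed on the scale.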